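Methoxyphenyl to Furanyl: Expected Effect on Paw Edema

The compounds below may be only part of what the source reports. "The series", "measured", "known", "first", "only" and "open" are said of these compounds alone.

Three compounds have so far been run in a functional assay on the whole organism (strain albino) for inhibition, with Rattus norvegicus as the target, read by paw edema, with stated times of 30 min and 2 h, at a dose of 100 mg/kg by the oral route; a lower number here means less inhibition, a higher number more inhibition at the dose given (going by the name of the read-out). Compound 1 `Nc1ccc(C(=O)/C=C/c2ccco2)cc1` gives 38%, compound 2 `O=C(CBr)Nc1ccc(C(=O)/C=C/c2ccco2)cc1` gives 37%, and compound 3 `COc1ccc(/C=C/C(=O)c2ccc(NC(=O)C(C)Br)cc2)cc1` gives 40%. Compound 3 thus sits alongside the other two, its value within the scatter of each of them. Going by the values given here, the only step measured across a single change, a number 1 percentage points lower from compound 1 to compound 2 (within the scatter), likewise stays within the scatter.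

Compound 4 `CC(Br)C(=O)Nc1ccc(C(=O)/C=C/c2ccco2)cc1` has not yet been measured. It differs from compound 3 in one place: furan-2-yl in place of 4-methoxyphenyl on a double-bonded chain carbon bound to a double-bonded chain carbon. Among the compounds with values here, no measured pair isolates this exchange; compound 1 and compound 2 already carry the furan-2-yl, while compound 3 alone carries the 4-methoxyphenyl, and all three numbers lie within the scatter of one another. Nothing in the data therefore points to a shift in either direction. Compound 4 is expected to show a step of a number 1 percentage points lower from compound 3 to compound 4 (within the scatter), which is no change beyond the scatter. Compound 4 is accordingly estimated at 39%, with a range from 30% to 48%.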

Compound 4, a percentage reported as inhibition, in the whole organism at one dose (the size of the read-out at that dose, not a potency): 37%
Estimate against measurement, compound 4: 2 percentage points above; the measured number falls inside the stated range.
By their numbers in this assay, from the lowest: compounds 2, 4, 1 and 3 (each within the scatter of the next).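

Reading the exchange directly in this assay, furan-2-yl in place of 4-methoxyphenyl on a double-bonded chain carbon bound to a double-bonded chain carbon gives a step (a number 3 percentage points lower from compound 3 to compound 4 (within the scatter)), so the two rings are not told apart at this place and this dose. On the other side of the molecule, methyl in place of hydrogen on a saturated chain carbon bound to a bromine atom and a carbonyl carbon gives a step (no change at the digits printed from compound 2 to compound 4 (within the scatter)), and the full (1-bromoethyl)carbonyl on a nitrogen on an aromatic ring gives another (a number 1 percentage points lower from compound 1 to compound 4 (within the scatter)). No evidence at hand bears on this result.

On these data alone, whether a dimethylamino group or a carboxylic acid at the place of the furan-2-yl would move the number beyond the scatter remains open. So does the outcome with a chlorine atom in place of the bromine atom.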